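Swapping ethyl for 2-fluorophenyl in compound 3

The source may report more compounds than this note shows. Statements on the series, on what has been measured and on what is new or still open speak of the compounds shown alone.

compound 1 `Fc1ccc(NC(=S)Nc2cccc(C(F)(F)F)c2)cc1Cl` gives 10000 nM
compound 2 `CCCCc1ccc(NC(=S)Nc2cccc(C(F)(F)F)c2)c(C)c1` gives 9000 nM
compound 3 `CCNC(=S)Nc1cccc(C(F)(F)F)c1` gives > 100000 nM

In an ADME assay on BHK cells (Mesocricetus auratus) for cytotoxicity, read by MTT assay, with a stated time of 96 h (a lower number here means that less compound is tolerated, a higher number that more compound is tolerated), compound 3 gives only a limit (> 100000 nM) and no exact number. The numbers for compound 1 and compound 2 lie within the usual scatter of each other. Compound 4 `Fc1ccccc1NC(=S)Nc1cccc(C(F)(F)F)c1` puts 2-fluorophenyl in place of ethyl on an amide-type nitrogen and is still unmeasured. An aromatic ring enters there, and compound 1 (10000 nM) and compound 2 (9000 nM) also carry one. For the measured compounds named here, no measured pair isolates this change, but a large downward step beyond the scatter is expected in this assay (an at least 6.6-fold lower number from compound 3 to compound 4 (0.82 log units; beyond the scatter)). Compound 4 is estimated at 15000 nM (expected range 5000 nM to 50000 nM).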

Compound 4, half-maximal cytotoxic concentration: 54000 nM
Estimate against measurement, compound 4: 3.6-fold (0.56 log units) below, and the stated range ends below it.
By their numbers in this assay, from the lowest: compounds 2 and 1 (each within the scatter of the next); then compound 4. At a limit, above all of these: compound 3.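

For the compounds shown here, this is the first pair that differs only at this nitrogen: in this assay, 2-fluorophenyl in place of ethyl gives an at least 1.8-fold lower number from compound 3 to compound 4 (0.26 log units; that floor lies within the scatter). The swap therefore turns a limit into an exact value, but the pair does not establish a real fall in the number. Only a floor can be read for this step because compound 3 stands at a limit: the limit of > 100000 nM in this assay, at which 1 of the 4 values shown sits.

The compounds shown leave open how a longer chain or an unsubstituted phenyl on this nitrogen would read. They also leave open whether the fluorine of 2-fluorophenyl matters here.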